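Shifting the Methoxy Group of Compound 1

This account rests on a few compounds, and the source may have more. Where it says the series, first, only, none or still open, it means among the compounds named here.

Of the compounds shown here, three built on a shared core have been measured in a functional assay on MCF7 cells (Homo sapiens) for cytotoxicity, read by sulforhodamine B assay, with a stated time of 48 h; on this read-out lower numbers stand for stronger inhibition and higher numbers for weaker inhibition. Compound 1 `COc1ccc(/C=C/C(=O)c2cccc(-c3cccc(F)c3)c2)cc1` gives 3080 nM in this assay, the lowest of the three numbers. Compound 3 `COc1ccc(-c2cc(C(=O)/C=C/c3cccc(OC)c3OC)ccc2N)cc1OC` gives 10200 nM, a reading that lies beyond the scatter above that of compound 1, and compound 2 `Nc1ccc(C(=O)/C=C/c2ccc(O)c(F)c2)cc1-c1ccc(F)cc1` gives 18300 nM, further away still. No pair among these three differs in only one place, so no single step between measured compounds can be read off.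

Compound 4 `COc1ccccc1/C=C/C(=O)c1cccc(-c2cccc(F)c2)c1` has not yet been measured. It shares every atom with compound 1, joined differently: 2-methoxyphenyl in place of 4-methoxyphenyl on a double-bonded chain carbon bound to a double-bonded chain carbon. Going by the values given here, nothing among the measured compounds isolates this kind of rearrangement; the ring that carries the methoxy group does vary within the set, but always together with other parts of the molecule, as in compound 3. The expectation therefore rests on the modest size of the change alone. The account expects a step from compound 1 to compound 4 of a 1.2-fold higher number from compound 1 to compound 4 (0.09 log units; within the scatter), that is, nothing beyond the scatter, perhaps leaning toward a weaker number. For compound 4 the estimate in this assay is 3800 nM, with a range from 1300 nM to 11000 nM.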

Compound 4, half-maximal inhibitory concentration: 18900 nM
Estimate against measurement, compound 4: 5.0-fold (0.70 log units) below; measured number above the stated range.
By their numbers in this assay, from the lowest: compound 1; then compounds 3, 2 and 4 (each within the scatter of the next).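

In this assay, the place of the methoxy group proves to count: 2-methoxyphenyl in place of 4-methoxyphenyl on a double-bonded chain carbon bound to a double-bonded chain carbon gives a 6.1-fold higher number from compound 1 to compound 4 (0.79 log units; beyond the scatter), although the two groups have the same heavy atoms, hydrogen-bond donors and hydrogen-bond acceptors by count. The earlier compounds shown here could not show this, as the ring carrying the methoxy group varied in them only together with other parts of the molecule, whereas here one rearrangement of the same atoms is seen alone, and the 4-methoxyphenyl group goes with the lower number. Nothing given here accounts for the size of this step.

Going by these compounds, it remains open whether the step belongs to the methoxy group in particular or would also appear with another group moved in the same way, such as an ethoxy group or a dimethylamino group. On these data alone, it is also open whether the same shift would carry the same weight on a core bearing the amine seen in compound 2 and compound 3, as a single pair cannot settle this.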